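Changing the Side-Chain Amine of Compound 3

The compounds below may be only part of what the source reports. "The series", "measured", "known", "first", "only" and "open" are said of these compounds alone.

In a functional assay on MGC-803 cells (Homo sapiens) for cytotoxicity, read by MTT assay, with stated times of 48 h and 4 h (on this read-out lower numbers stand for stronger inhibition and higher numbers for weaker inhibition), compound 1 `CCN(CC)CCNc1nc(/C=C/c2ccc(OC)c(OC)c2)nc2ccccc12` stands at > 100000 nM which is a limit and not a number.

Compound 2 `COc1ccc(/C=C/c2nc(NCCN(C(C)C)C(C)C)c3ccccc3n2)cc1OC` gives 15500 nM and compound 3 `CC(C)N(CCNc1nc(/C=C/c2ccc([N+](=O)[O-])cc2)nc2ccccc12)C(C)C` gives 29100 nM so these two sit level, and the step of a 1.9-fold higher number from compound 2 to compound 3 (0.27 log units; within the scatter) changes another part of the molecule.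

Compound 4 `NCCCCNc1nc(/C=C/c2ccc([N+](=O)[O-])cc2)nc2ccccc12` carries 2-aminoethyl in place of diisopropylamino on a saturated chain carbon, two bonds along the chain from a nitrogen on an aromatic ring on a saturated chain carbon, two bonds along the chain from a nitrogen on an aromatic ring.

Among the measured compounds shown here, only the step of an at least 6.4-fold lower number from compound 1 to compound 2 (0.80 log units; beyond the scatter) bears on this place, and there diisopropylamino brought the lower number.

A modest move to a higher number is therefore expected, as the estimated step of a 1.4-fold higher number from compound 3 to compound 4 (0.14 log units; within the scatter) in this assay shows.

For compound 4 the estimate is 40000 nM with an expected range from 10000 nM to 100000 nM in all.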

Compound 4, half-maximal inhibitory concentration: 1730 nM
Beside the measured number, compound 4's estimate is 23-fold (1.36 log units) above it; the measured number lies below the stated range.
By their numbers in this assay, from the lowest: compound 4; then compounds 2 and 3 (each within the scatter of the next). At a limit, above all of these: compound 1.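

The step, a 17-fold lower number from compound 3 to compound 4 (1.23 log units; beyond the scatter) in this assay, shows that this position can move the number much further than the swap of diethylamino for diisopropylamino revealed. Here the group with 3 heavy atoms in place of 7 gives the lower number, while the earlier swap favoured diisopropylamino, so group size alone does not set the order. Nothing measured here explains this step.

Cut further out, 2-(diisopropylamino)ethyl becomes 4-aminobutyl, so chain length and end group change together. A 4-(diisopropylamino)butyl or 4-hydroxybutyl chain would help separate them.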